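The source may report more compounds than this note shows. Statements on the series, on what has been measured and on what is new or still open speak of the compounds shown alone.

Measured in a functional assay on K562 cells (Homo sapiens) for antiproliferative activity, read by MTT assay, with a stated time of 48 h; on this read-out higher numbers stand for weaker inhibition and lower numbers for stronger inhibition:
- Compound 1 `CC[C@@H](C)[C@H](NC(=O)c1ccc(Oc2nc3ccccc3nc2C)cc1)C(=O)O`: 30500 nM
- Compound 2 `COC(=O)[C@H](CC(C)C)NC(=O)c1ccc(Oc2nc3ccccc3nc2NC(C)(C)C)cc1`: > 50000 nM

Compound 2 stands at > 50000 nM in this assay, which is a limit and not a number. Compound 3 `CC[C@@H](C)[C@H](NC(=O)c1ccc(Oc2nc3ccccc3nc2NC(C)(C)C)cc1)C(=O)O` carries 1-carboxy-2-methylbutyl in place of 1-(methoxycarbonyl)-3-methylbutyl on an amide-type nitrogen. Compound 1 also bears 1-carboxy-2-methylbutyl and gives 30500 nM, so a modest move toward stronger inhibition is expected. A result for compound 3 still at the limit would be no surprise. The expected change is an at least 1.6-fold lower number from compound 2 to compound 3 (0.22 log units; that floor lies within the scatter). For compound 3 the estimated value is 30000 nM, with an expected range of 10000 nM to 60000 nM.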

Compound 3, half-maximal inhibitory concentration: 18300 nM
Compound 3: the middle estimate sits 1.6-fold (0.21 log units) above what was measured; the measured number falls inside the stated range.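

Putting 1-carboxy-2-methylbutyl in place of 1-(methoxycarbonyl)-3-methylbutyl on an amide-type nitrogen gives an at least 2.7-fold lower number from compound 2 to compound 3 (0.43 log units; beyond the scatter) in this assay, a change that lies beyond the scatter. On these data alone, its full size stays open, as compound 2 is known only by a limit and not a number: the limit of > 50000 nM in this assay, at which 1 of the 3 values shown sits. With 1-carboxy-2-methylbutyl held fixed, (tert-butyl)amino in place of methyl on an aromatic carbon gives a 1.7-fold lower number from compound 1 to compound 3 (0.22 log units; within the scatter), so the two are not told apart here.

The step changes the methyl ester to a carboxylic acid and alters the chain together, leaving open which part matters. 1-Carboxy-3-methylbutyl or 1-(methoxycarbonyl)-2-methylbutyl on that nitrogen would separate them.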